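Chain Length on the Exocyclic Nitrogen of a Diaminopurine Core

The source may report more compounds than this note shows. Statements on the series, on what has been measured and on what is new or still open speak of the compounds shown alone.

Measured compounds:
- compound 1, `Nc1n/c(=N\CCCCc2ccccc2)nc(N)c2c1ncn2Cc1ccccc1`: 8800 nM
- compound 2, `CCCCCCCCCCCCCCCCCC/N=c1\nc(N)c2ncn(Cc3ccccc3)c2c(N)n1`: 8300 nM
- compound 3, `CCCCCCCCCC/N=c1\nc(N)c2ncn(Cc3ccccc3)c2c(N)n1`: 1400 nM

Three compounds share one core and differ only in the chain on the double-bonded nitrogen. In a functional assay on MCF7 cells (Homo sapiens) for antiproliferative activity, read by WST assay, with a stated time of 72 h (a lower number here means a stronger inhibitor, a higher number a weaker inhibitor), compound 1 gives the highest of the three numbers; compound 2 sits within the scatter of it, and compound 3 is clearly apart, with a 6.3-fold lower number from compound 1 to compound 3 (0.80 log units; beyond the scatter). Compound 2 to compound 3 shows the same direction, a 5.9-fold lower number from compound 2 to compound 3 (0.77 log units; beyond the scatter).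

Compound 4, `CCCCCCCC/N=c1\nc(N)c2ncn(Cc3ccccc3)c2c(N)n1`, has not yet been measured. It differs from compound 1 in one place: butyl in place of phenyl on a saturated chain carbon, four bonds along the chain from a double-bonded nitrogen

The step from compound 1 to compound 3 is the closest guide, since it too exchanges the phenyl on that chain carbon for an alkyl chain, there hexyl; here the chain is two carbons shorter. The step from compound 2 to compound 3 shows that shortening a plain chain also lowered the number, though compound 4 carries a shorter chain than compound 3, so the size reached by compound 3 may not be matched. Compound 4 is therefore expected to sit between compound 1 and compound 3, with an estimated 3.3-fold lower number from compound 1 to compound 4 (0.51 log units; beyond the scatter). The estimate for compound 4 is 2700 nM, in a range of 1100 nM to 6500 nM.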

Compound 4, half-maximal inhibitory concentration: 4550 nM
Estimate against measurement, compound 4: 1.7-fold (0.23 log units) below, within the range that was stated.
By their numbers in this assay, from the lowest: compound 3; then compounds 4, 2 and 1 (each within the scatter of the next).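

The exchange of phenyl for butyl on a saturated chain carbon, four bonds along the chain from a double-bonded nitrogen, gives a 1.9-fold lower number from compound 1 to compound 4 (0.29 log units; within the scatter) in this assay, so replacing the ring with a plain chain does not by itself set a compound apart here. The low number of compound 3 therefore depends on more than the loss of phenyl, since taking ethyl off the end of its chain gives a 3.3-fold higher number from compound 3 to compound 4 (0.51 log units; beyond the scatter) and the clear gain seen with hexyl at the same place is lost. For the compounds shown here, the much longer chain of compound 2 and the shorter chain of compound 4 cannot be told apart, with a 1.8-fold lower number from compound 2 to compound 4 (0.26 log units; within the scatter), which leaves compound 3 as the only compound clearly separated from the others, and the number does not follow chain length in a steady direction.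

Nothing available here explains these differences. Still open, from the compounds shown here alone, is how a nonyl or dodecyl chain would compare with compound 3, and what an amine or a carboxylic acid at the end of the chain would do to the number.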